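A few compounds are considered here, and "the series" means these few. Any claim that something is new, unique, unknown or untested is made for them only; others in the source may bear on it.

Compound 1 `O=C(Nc1cccc(F)c1)N[C@H]1CC[C@H](Oc2ccc(F)cc2)CC1` is the point of reference. In a functional assay on CRL2813 cells (Homo sapiens) for cytotoxicity, read by sulforhodamine B assay, with a stated time of 5 days (on this read-out lower numbers stand for stronger inhibition and higher numbers for weaker inhibition), compound 1 gives 8300 nM, the highest of the two numbers in hand, with compound 2 nearest to it. Compound 2 `O=C(Nc1cccc(Cl)c1)N[C@H]1CC[C@H](Oc2ccc(F)cc2)CC1` gives 5900 nM in this assay, and the step of a 1.4-fold lower number from compound 1 to compound 2 (0.15 log units; within the scatter) shows that exchanging one halogen for another on that aromatic carbon barely moves the read-out. Compound 3 `O=C(Nc1ccccc1OC(F)(F)F)N[C@H]1CC[C@H](Oc2ccc(F)cc2)CC1` is recorded in this assay only as a limit, > 20000 nM, which is the limit of > 20000 nM in this assay, at which 1 of the 3 values shown sits, and not a number.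

Compound 4 `O=C(Nc1ccccc1)N[C@H]1CC[C@H](Oc2ccc(F)cc2)CC1` has yet to be measured. Against compound 1 the change is hydrogen in place of fluoro on an aromatic carbon. Within the data shown here, the only measured step that touches the same aromatic carbon is a 1.4-fold lower number from compound 1 to compound 2 (0.15 log units; within the scatter), and it stayed within the scatter. Among the measured compounds shown here, no measured step covers removal of the substituent outright, so the expectation rests on that single comparison. No step beyond the scatter is expected in this assay for compound 4, in either direction. Compound 4 is therefore estimated at 9000 nM, within a range of 4000 nM to 20000 nM. The expected step of a 1.1-fold higher number from compound 1 to compound 4 (0.04 log units; within the scatter) is essentially flat.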

Compound 4, half-maximal inhibitory concentration: 20000 nM
Compound 4: the middle estimate sits 2.2-fold (0.35 log units) below what was measured, within the range that was stated.
By their numbers in this assay, from the lowest: compounds 2 and 1 (each within the scatter of the next); then compound 4.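

In this assay, removing the halogen does what exchanging it did not: a 2.4-fold higher number from compound 1 to compound 4 (0.38 log units; beyond the scatter), and a 3.4-fold higher number from compound 2 to compound 4 (0.53 log units; beyond the scatter), both modest steps but beyond the scatter. Fluoro and chloro at this aromatic carbon stay within the scatter of each other, so among the compounds shown, either halogen goes with a lower number than hydrogen, and which halogen it is makes no readable difference. The remaining step reads a number no higher from compound 3 to compound 4 (the limit leaves the size open) and its size cannot be read. Compound 3 is a limit and not a number: the limit of > 20000 nM in this assay, at which 1 of the 4 values shown sits.

On these data alone, whether a bromo, methyl, methoxy or amine on this aromatic carbon would track the halogens or hydrogen remains open. Also open, as far as these compounds go, is whether the gain seen with the halogens would hold on a different core.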